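The compounds below may be only part of what the source reports. "The series", "measured", "known", "first", "only" and "open" are said of these compounds alone.

Measured in an ADME assay on J774.1 cells (Mus musculus) for cytotoxicity, read by resazurin assay, with a stated time of 48 h; a higher number here means a weaker inhibitor, a lower number a stronger inhibitor:

- Compound 1 `CCCn1cc(C(=O)NCc2ccc(OC)cc2)c(=O)c2cc(F)c(N3CCC(C(N)=O)CC3)cc21`: 41400 nM
- Compound 2 `NC(=O)C1CCN(c2cc3c(cc2F)c(=O)c(C(=O)O)cn3C2CC2)CC1`: > 100000 nM

The reading for compound 2 is a limit of the assay and not a number, and it stands as the limit of > 100000 nM in this assay, at which 1 of the 2 values shown sits. Compound 3 `COc1ccc(CNC(=O)c2cn(C3CC3)c3cc(N4CCC(C(N)=O)CC4)c(F)cc3c2=O)cc1` is compound 2 with (4-methoxybenzyl)amino in place of hydroxy on a carbonyl carbon. Compound 1 also carries the (4-methoxybenzyl)carbamoyl and gives 41400 nM, so a step beyond the scatter, towards a lower number, is expected in this assay. The estimated step is an at least 2.2-fold lower number from compound 2 to compound 3 (0.34 log units; beyond the scatter). For compound 3 the expected value is 45000 nM, with an estimated range of 18000 nM to 100000 nM.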

Compound 3, half-maximal inhibitory concentration: > 100000 nM
Compound 3 gave a limit, no number (the forecaster's own chance of this, stated with the estimate: 15%); at least 2.2-fold (0.34 log units) between middle value and limit.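

In this assay, cyclopropyl in place of propyl on an aromatic nitrogen, with the (4-methoxybenzyl)carbamoyl kept, gives an at least 2.4-fold higher number from compound 1 to compound 3 (0.38 log units; beyond the scatter), the first readable sign that the group on this nitrogen matters here. The step from carboxy to (4-methoxybenzyl)carbamoyl cannot be read, as compound 2 and compound 3 each give a limit and not a number: the limit of > 100000 nM in this assay, at which 2 of the 3 values shown sit.

Still open, from the compounds shown here alone, is how far apart compound 2 and compound 3 truly lie. Also open, going by these compounds, is how a butyl chain on that nitrogen, or a simple primary amide on the carbonyl carbon, would read in this assay.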